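Oral Tail Flick Activity: Glutamate to Leucine Side Chain

This account rests on a few compounds, and the source may have more. Where it says the series, first, only, none or still open, it means among the compounds named here.

In a functional assay on the whole organism (Tail, strain ICR) with Mus musculus as the target, in the tail flick test, with a stated time of 30 min, at a dose of 25 umol/kg by the oral route (on this read-out lower numbers stand for a weaker effect and higher numbers for a stronger effect at the one dose given), compound 1 `O=C(O)CC[C@H](NC(=O)CN(c1nc(Cl)nc2[nH]cnc12)C1CC1)C(=O)O` gives 26.8%. Compound 3 `NC(=O)CC[C@H](NC(=O)CN(c1nc(Cl)nc2[nH]cnc12)C1CC1)C(=O)OCc1ccccc1` gives 30.8%, and compound 2 `CC(C)(C)OC(=O)NCCCC[C@H](NC(=O)CN(c1ncnc2c1ncn2C1CCCCO1)C1CC1)C(=O)OCc1ccccc1` gives 18.3%; compound 1 sits second of the three, and the gaps to compound 3 and to compound 2 both lie within the scatter, so no ordering among the measured compounds can be read from these numbers. Compound 4 `CC(C)C[C@H](NC(=O)CN(c1nc(Cl)nc2[nH]cnc12)C1CC1)C(=O)O` has not been measured. It differs from compound 1 by isopropyl in place of carboxymethyl on a saturated chain carbon, two bonds along the chain from an amide-type nitrogen and a carbonyl carbon. Among the measured compounds shown here, no measured pair shows this change, so the step from compound 1 to compound 4 is expected to be small, a number 3.2 percentage points higher from compound 1 to compound 4 (within the scatter), with no direction beyond the scatter. Compound 4 is therefore estimated at 30%, with a range from 12% to 50%.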

Compound 4, a percentage reported as activity, at one dose (the size of the read-out at that dose, not a potency): 23.4%
For compound 4 the middle estimate is 6.6 percentage points above the measured one, within the range that was stated.
By their numbers in this assay, from the lowest: compounds 2, 4, 1 and 3 (each within the scatter of the next, the first and the last beyond it).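

In this assay, among the compounds shown here, isopropyl in place of carboxymethyl on this saturated chain carbon gives a number 3.4 percentage points lower from compound 1 to compound 4 (within the scatter) and is the first single-place change available. At this position, removing the carboxylic acid of the carboxymethyl group, with its hydrogen-bond donor and acceptor, therefore leaves the read-out within the scatter at the one dose given. No measured information bears on why this is so.

Going by these compounds, whether a free amine or a hydroxyl on this carbon would move the read-out beyond the scatter remains open. A single dose also leaves any difference in potency between these side chains unresolved.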